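A few compounds are considered here, and "the series" means these few. Any claim that something is new, unique, unknown or untested is made for them only; others in the source may bear on it.

Two members of the series carry numbers in a functional assay on MDA-MB-231 cells (Homo sapiens) for inhibition, read by sulforhodamine B assay, tested at 10 uM; a lower number here means less inhibition, a higher number more inhibition at the concentration tested (going by the name of the read-out). Compound 1 `CN(C)c1ccc(C2CC(c3ccc(-n4cncn4)cc3)=NN2C(=O)c2ccc(F)cc2)cc1` gives 12.5% in this assay. Compound 2 `Cc1ccc(S(=O)(=O)N2N=C(c3ccc(-n4cncn4)cc3)CC2c2ccc(N(C)C)cc2)cc1` gives 20.7% in this assay and so stands as the higher of the two numbers, though the step of a number 8.2 percentage points higher from compound 1 to compound 2 (within the scatter) lies within the scatter, so the two compounds cannot be told apart. Among the compounds with values here, that step concerns the group on the amine nitrogen in the ring and is the only measured comparison available.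

Compound 3 `CN(C)c1ccc(C2CC(c3ccc(-n4cncn4)cc3)=NN2S(=O)(=O)c2ccc(OC(F)(F)F)cc2)cc1` keeps the core of compound 2 and differs in one place: trifluoromethoxy in place of methyl on an aromatic carbon. Within the data shown here, no measured step touches a substituent on the 4-methylphenyl of compound 2, so the expectation for this assay rests on the flat outcome of the single step that exists. A step of a number 0.7 percentage points lower from compound 2 to compound 3 (within the scatter) is expected, nothing beyond the scatter. Compound 3 is therefore estimated at 20% in this assay, with a range from 5% to 40%.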

Compound 3, a percentage reported as inhibition, at one concentration (the size of the read-out at that concentration, not a potency): 18.5%
For compound 3 the middle estimate is 1.5 percentage points above the measured one, and the stated range covers the measured number.
By their numbers in this assay, from the lowest: compounds 1, 3 and 2 (each within the scatter of the next).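

Trifluoromethoxy in place of methyl on the aromatic carbon para to a large group gives a number 2.2 percentage points lower from compound 2 to compound 3 (within the scatter) in this assay, so compound 2 and compound 3 cannot be told apart. Within the data shown here, this is the first reading at this position, as the earlier step concerned only the group on the ring nitrogen; here a group of five heavy atoms with one hydrogen-bond acceptor enters for a single carbon without a step beyond the scatter. Nothing available on these compounds offers an explanation for this result.

From the compounds shown here alone, whether an amine, a carboxylic acid or a longer chain at this position would give a step beyond the scatter remains open. The compounds shown also leave open how far this reading holds on a different core, since each one here keeps the same core.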